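Shifting one hydroxyl on a triaryl pyridine core

The compounds below may be only part of what the source reports. "The series", "measured", "known", "first", "only" and "open" are said of these compounds alone.

Measured compounds:
compound 1, `Oc1ccc(-c2cc(-c3cccc(O)c3)cc(-c3ccc(O)cc3)n2)cc1`, 4070 nM
compound 2, `Oc1ccc(-c2cc(-c3cccc(O)c3)cc(-c3ccccc3O)n2)cc1`, 50000 nM

Compound 1 holds the lower of the two numbers in a functional assay on T47D cells (Homo sapiens) for cytotoxicity, read by CCK-8 assay, with a stated time of 4 days; on this read-out higher numbers stand for weaker inhibition and lower numbers for stronger inhibition; compound 2 is the nearer neighbour, and the change a 12-fold higher number from compound 1 to compound 2 (1.09 log units; beyond the scatter) separates them. Compound 3 `Oc1ccc(-c2cc(-c3ccccc3O)cc(-c3ccc(O)cc3)n2)cc1` has not yet been measured. It differs from compound 1 by 2-hydroxyphenyl in place of 3-hydroxyphenyl on an aromatic carbon, the new group sitting opposite the ring nitrogen of the shared core. For the measured compounds named here, only one measured step bears on this: the move from compound 1 to compound 2 also introduced a 2-hydroxyphenyl group, there in place of a 4-hydroxyphenyl, and it gave a 12-fold higher number from compound 1 to compound 2 (1.09 log units; beyond the scatter). Because of a 12-fold higher number from compound 1 to compound 2 (1.09 log units; beyond the scatter), a weakening well beyond the scatter is expected for compound 3 in this assay too, though perhaps less steep, since the two 4-hydroxyphenyl groups of compound 1 are retained. The expected step is a 4.9-fold higher number from compound 1 to compound 3 (0.69 log units; beyond the scatter). Compound 3 is estimated at 20000 nM, with a range from 6000 nM to 60000 nM.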

Compound 3, half-maximal inhibitory concentration: 5350 nM
The estimate for compound 3 lay 3.7-fold (0.57 log units) above the measured number; the whole stated range lies above it.
By their numbers in this assay, from the lowest: compounds 1 and 3 (each within the scatter of the next); then compound 2.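

In this assay, placing 2-hydroxyphenyl in place of 3-hydroxyphenyl opposite the ring nitrogen gives a 1.3-fold higher number from compound 1 to compound 3 (0.12 log units; within the scatter), so at this position the two hydroxyl placements cannot be told apart. The same 2-hydroxyphenyl group does not give the same result everywhere on the shared core: in place of a 4-hydroxyphenyl it gave a 12-fold higher number from compound 1 to compound 2 (1.09 log units; beyond the scatter). No measurement shown here accounts for this contrast.

The compounds shown leave open whether the hydroxyl matters at all at the position opposite the ring nitrogen, a question that an unsubstituted phenyl or a methoxyphenyl group there would address. They also leave open how this position responds to a group of another kind, such as an aminophenyl or a carboxylic acid.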